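The source may report more compounds than this note shows. Statements on the series, on what has been measured and on what is new or still open speak of the compounds shown alone.

In a functional assay on H22 cells (Mus musculus) for inhibition, read by MTT assay, with a stated time of 24 h (a lower number here means a stronger inhibitor, a higher number a weaker inhibitor), compound 1 `O=[N+]([O-])c1cc(Cl)ccc1CNc1cc(C(F)(F)F)cc2[nH]ncc12` gives 10300 nM and compound 2 `O=[N+]([O-])c1ccc(Cl)cc1CNc1cc(C(F)(F)F)cc2[nH]ncc12` gives 490 nM. That is the lower of the two numbers, with a gap beyond the scatter. Compound 3 `O=[N+](O)c1c(Cl)cccc1CNc1cc(C(F)(F)F)cc2[nH]ncc12` reaches only a limit of the assay, > 20000 nM. Compound 4 `O=[N+]([O-])c1ccccc1CNc1cc(C(F)(F)F)cc2[nH]ncc12` has not yet been measured. It departs from compound 2 by hydrogen in place of chloro on an aromatic carbon. Going by the values given here, no measured step isolates this change. Among the compounds with values here, with compound 2 at 490 nM, the lowest number so far, a moderate rise in this assay is expected rather than a fall. The expected change is a 4.1-fold higher number from compound 2 to compound 4 (0.61 log units; beyond the scatter). For compound 4 the estimated value is 2000 nM, within an expected range of 500 nM to 10000 nM.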

Compound 4, half-maximal inhibitory concentration: 9010 nM
Compound 4: middle estimate off by 4.5-fold (0.65 log units), on the low side; the range from low to high includes it.
By their numbers in this assay, from the lowest: compound 2; then compounds 4 and 1 (each within the scatter of the next). At a limit, above all of these: compound 3.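

In this assay, taking away the chloro para to a nitro group is a large loss (an 18-fold higher number from compound 2 to compound 4 (1.26 log units; beyond the scatter)), so the chloro at this place accounts for the lower number of compound 2. The chloro of compound 1 sits at a different place, and its removal changes nothing beyond the scatter (a 1.1-fold lower number from compound 1 to compound 4 (0.06 log units; within the scatter)). Among these three compounds, then, the gain belongs to chloro at this one place, not to chloro as such. As far as these compounds go, whether a fluoro, a methyl or a methoxy at this place would keep the gain remains open. Nothing shown here explains the size of this step.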